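Methyl in place of cyano in compound 4

A few compounds are considered here, and "the series" means these few. Any claim that something is new, unique, unknown or untested is made for them only; others in the source may bear on it.

Within the data shown here, in a functional assay on HeLa cells (Homo sapiens) for antiproliferative activity, read by sulforhodamine B assay, with a stated time of 72 h (a higher number here means a weaker inhibitor, a lower number a stronger inhibitor), compound 3 (`N#Cc1ccc(NC(=S)N/N=C/c2ccc3ccccc3n2)cc1`) gives 20000 nM, the only actual number so far. Compound 1 (`COc1ccc(C)cc1NC(=S)N/N=C/c1ccc2ccccc2n1`) gives > 100000 nM, which is a limit. Compound 2 (`Fc1ccccc1NC(=S)N/N=C/c1ccc2ccccc2n1`) gives > 100000 nM, also a limit. Compound 4 (`Cc1ccc(NC(=S)N/N=C/c2ccc3ccccc3n2)cc1`) has methyl in place of cyano on an aromatic carbon, para to a large group: methyl in place of cyano on an aromatic carbon. Among the measured compounds shown here, one measured step bears on this change: an at least 5.0-fold lower number from compound 2 to compound 3 (0.69 log units; beyond the scatter), with 4-cyanophenyl replacing 2-fluorophenyl. Losing the cyano may therefore give back some of that gain, and the result could reach (the limit of > 100000 nM in this assay, at which 2 of the 3 values shown sit). The expected change is a 2.5-fold higher number from compound 3 to compound 4 (0.40 log units; beyond the scatter), toward weaker inhibition. Compound 4 is estimated at 50000 nM, with an expected range from 20000 nM to 100000 nM.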

Compound 4, half-maximal inhibitory concentration: 86000 nM
Compound 4: the middle estimate sits 1.7-fold (0.24 log units) below what was measured; low and high end bracket the measured number.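

With methyl in place of cyano on an aromatic carbon, this assay shows a 4.3-fold higher number from compound 3 to compound 4 (0.63 log units; beyond the scatter). This ties the earlier gain to the cyano group itself, not simply to having a group at this place, para to a large group. The comparison with the 2-fluorophenyl compound gives an at least 1.1-fold lower number from compound 2 to compound 4 (0.06 log units; that floor lies within the scatter), so it separates neither compound from the other.

From the compounds shown here alone, whether an amine or a carboxylic acid at this place would match compound 3 remains open. The true standing of compound 1 and compound 2 also remains open: the limit of > 100000 nM in this assay, at which 2 of the 4 values shown sit.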